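A few compounds are considered here, and "the series" means these few. Any claim that something is new, unique, unknown or untested is made for them only; others in the source may bear on it.

Measured compounds in a functional assay on HL-60 cells (Homo sapiens) for antiproliferative activity, read by sulforhodamine B assay, with a stated time of 72 h; a higher number here means a weaker inhibitor, a lower number a stronger inhibitor:
- compound 1 `S=C(N/N=C/c1ccc2ccccc2n1)Nc1cccc(Cl)c1`: 28800 nM
- compound 2 `Cc1csc2sc(/C=N/NC(N)=S)c(C)c12`: > 100000 nM, a limit of the assay rather than a number
- compound 3 `CC(C)c1cccc(C(C)C)c1NC(=S)N/N=C/c1ccc2ccccc2n1`: 19500 nM

Compound 1 holds the higher of the two numbers obtained in this assay. Its nearest neighbour is compound 3, whose value sits within the usual scatter of compound 1, so the two cannot be told apart. Compound 2 contributes only a limit, (the limit of > 100000 nM in this assay, at which 1 of the 3 values shown sits), and gives no number to compare.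

Among the measured compounds shown here, no pair of measured compounds differs in a single place, so no measured step is available to set the size of a change on the aryl substituent of the thiosemicarbazone.

Compound 4 `S=C(N/N=C/c1ccc2ccccc2n1)Nc1ccccc1Br` is the next member to be measured. It differs from compound 1 in one place: 2-bromophenyl in place of 3-chlorophenyl on an amide-type nitrogen. The shared core of compound 1 is kept unchanged.

For the measured compounds named here, with no measured step to lean on, the expectation for compound 4 is conservative: a small shift at most, in either direction, and most likely none beyond the scatter. The step from compound 1 to compound 4 is expected to be a 1.1-fold lower number from compound 1 to compound 4 (0.04 log units; within the scatter). Compound 4 is estimated at 26000 nM, with a range from 8000 nM to 85000 nM.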

Compound 4, half-maximal inhibitory concentration: > 100000 nM
Compound 4 was reported as a limit; the forecaster's own chance of this, stated with the estimate: 12%; at least 3.8-fold (0.58 log units) between middle value and limit.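

In this assay, among the compounds shown here, 2-bromophenyl in place of 3-chlorophenyl on the amide-type nitrogen gives an at least 3.4-fold higher number from compound 1 to compound 4 (0.54 log units; beyond the scatter), the first measured step, so activity here is not indifferent to an exchange of one halogen-bearing phenyl group for another while the shared core stays unchanged. Compound 4 gives > 100000 nM, which is a limit of the assay and not a number. The step therefore sets only a lower bound on the size of this change, and its true size remains unknown, with the top of the range of this read-out reached here: the limit of > 100000 nM in this assay, at which 2 of the 4 values shown sit.

Going by these compounds, what remains open is whether the weakening follows the identity of the halogen or its place on the phenyl ring, a question that 2-chlorophenyl and 3-bromophenyl groups on the same nitrogen would separate. Also open, on these data alone, is whether a methoxy or an amino group on this phenyl ring would keep activity in the range of compound 1, which gives 28800 nM.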